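The compounds below may be only part of what the source reports. "The series", "measured", "known", "first", "only" and "open" are said of these compounds alone.

Among the compounds with values here, compound 1 (`Cc1noc(C)c1[C@@H]1C[C@@](C)(c2sccc2Cl)N=C(N)S1`) and compound 2 (`Cc1noc(-c2ccccc2)c1[C@@H]1C[C@@](C)(c2ccc(F)cc2F)N=C(N)S1`) are the only measured members so far. In an ADME assay on microsomes from liver (Mus musculus) for metabolic stability, with a stated time of 10 min, tested at 0.5 uM (a lower number here means that less of the compound is left, a higher number that more of the compound is left), compound 2 gives 6% and stands lowest of the two. Compound 1 gives 21% in the same read-out. The gap between the two lies beyond the scatter. Compound 3 (`Cc1nocc1[C@@H]1C[C@@](C)(c2ccc(F)cc2F)N=C(N)S1`) has hydrogen in place of phenyl on an aromatic carbon. Within the data shown here, no measured pair isolates this change. The estimated step of a number 22 percentage points higher from compound 2 to compound 3 (beyond the scatter) in this assay is expected as a rise beyond the scatter, a reading that leans only on compound 1, which also lacks the phenyl and gives 21% there. The expected value for compound 3 is 28% within an estimated range of 12% to 50% for now.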

Compound 3, percent of the compound remaining: 80%
Beside the measured number, compound 3's estimate is 52 percentage points below it; measured number above the stated range.
By their numbers in this assay, from the lowest: compound 2; then compound 1; then compound 3.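

Within the data shown here, compound 2 and compound 3 form the first measured pair that isolates hydrogen in place of phenyl on an aromatic carbon, and in this assay this gives a number 74 percentage points higher from compound 2 to compound 3 (beyond the scatter). The read-out at this position is therefore highly sensitive to this single change, with the rest of the structure held constant. Nothing at hand accounts for the size of the step.

On these data alone, whether an amine or a methoxy group on this carbon would give a number nearer compound 2 or compound 3 remains open. Also open, as far as these compounds go, is whether the step would carry over to other groups elsewhere on the shared core.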